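Removing a methoxy group from compound 2: an expectation

The compounds below may be only part of what the source reports. "The series", "measured", "known", "first", "only" and "open" are said of these compounds alone.

The measured compounds, with their results in a functional assay on the whole organism (strain albino) for inhibition, with Rattus norvegicus as the target, read by paw edema, with stated times of 1 h and 3 h, at a dose of 20 mmol/kg by the intraperitoneal route; a lower number here means a weaker effect, a higher number a stronger effect of the compound at the dose given:
- compound 1, `N#CC1=C(NCN2CCCC2)N(c2ccccc2)C(=O)N2CCCCC(N3CCCC3)C12`, gives 35.3%
- compound 2, `COc1ccc(N/C=N/C2=C(C#N)C3C(N4CCCC4)CCCCN3C(=O)N2c2ccccc2)cc1`, gives 50.2%
- compound 3, `N#Cc1c2n(c(=O)n(-c3ccccc3)c1=N)CCCCC2N1CCCC1`, gives 93.4%

Compound 2 stands second highest of the three numbers in this assay: compound 1 lies beyond the scatter below it, compound 3 beyond the scatter above it. Among the compounds with values here, the only measured step, a number 14.9 percentage points higher from compound 1 to compound 2 (beyond the scatter), replaces one group on a double-bonded ring carbon by a larger one carrying a six-membered aromatic ring of carbon only, and it is modest.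

Compound 4, `N#CC1=C(/N=C/Nc2ccccc2)N(c2ccccc2)C(=O)N2CCCCC(N3CCCC3)C12`, differs from compound 2 by hydrogen in place of methoxy on an aromatic carbon. Within the data shown here, no measured step touches a methoxy group on that aromatic ring, so nothing among the measured compounds shows how much this change matters. Among the measured compounds shown here, with no step to lean on, the expectation is a change no larger than the scatter, so the estimated step of a number 0.2 percentage points lower from compound 2 to compound 4 (within the scatter) is expected to be small. Compound 4 is therefore estimated at 50%, within a range from 35% to 65% in this assay.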

Compound 4, a percentage reported as inhibition, in the whole organism at one dose (the size of the read-out at that dose, not a potency): 79.3%
Estimate against measurement, compound 4: 29.3 percentage points below, outside the stated range (above it).
By their numbers in this assay, from the lowest: compound 1; then compound 2; then compound 4; then compound 3.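

Removing the methoxy group, on an aromatic carbon para to a large group, is no silent change in this assay: it gives a number 29.1 percentage points higher from compound 2 to compound 4 (beyond the scatter) and so shows that this small group on the outer aromatic ring carries real weight. The phenyl form also changes the reading of the group on the double-bonded ring carbon, since replacing the group of compound 1 with the anilino-bearing group gives a number 44 percentage points higher from compound 1 to compound 4 (beyond the scatter) and this step is large, whereas the earlier step with the 4-methoxyphenyl group was modest. Nothing available gives a measured reason for the difference between methoxy and hydrogen here.

Going by these compounds, whether a methyl group, a chlorine atom or a hydroxyl group at this same place would read like hydrogen or like methoxy remains open. On these data alone, each number also comes from a single dose, so how the compounds compare across a range of doses is unknown.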